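This account rests on a few compounds, and the source may have more. Where it says the series, first, only, none or still open, it means among the compounds named here.

Compound 3 `COC(=O)NC[C@H]1CN(c2ccc(-n3cc(-c4ccccn4)cn3)c(F)c2)C(=O)O1` gives 34100 nM in a physicochemical assay for solubility, read by HPLC, with a stated time of 24 h (a lower number here means a less soluble compound, a higher number a more soluble compound), the lowest of the three numbers recorded. Compound 1 `CN1CCN(C[C@H]2CN(c3ccc(-n4cc(-c5ccccn5)cn4)c(F)c3)C(=O)O2)CC1` gives 1690000 nM and compound 2 `CC(=O)OC[C@H]1CN(c2ccc(-n3cc(-c4ccccn4)cn3)c(F)c2)C(=O)O1` gives 373000 nM. The steps of a 50-fold lower number from compound 1 to compound 3 (1.70 log units; beyond the scatter) and an 11-fold lower number from compound 2 to compound 3 (1.04 log units; beyond the scatter) show how strongly the group on the chain carbon moves this read-out, but every measured step changes that group, none the carbonyl substituent. Compound 4 `O=C(NC[C@H]1CN(c2ccc(-n3cc(-c4ccccn4)cn3)c(F)c2)C(=O)O1)C(F)F` differs from compound 3 by difluoromethyl in place of methoxy on a carbonyl carbon. Going by the values given here, with no measured step of this kind, the expectation rests on the direction set by the two large steps toward compound 3: a further modest fall, estimated as a 2.3-fold lower number from compound 3 to compound 4 (0.36 log units; beyond the scatter). Compound 4 is therefore expected to give about 15000 nM, within a range of 4000 nM to 60000 nM, in this assay.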

Compound 4, solubility: 29900 nM
The estimate for compound 4 lay 2.0-fold (0.30 log units) below the measured number, within the range that was stated.
By their numbers in this assay, from the lowest: compounds 4 and 3 (each within the scatter of the next); then compound 2; then compound 1.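

In this assay, the step at the carbonyl carbon, difluoromethyl in place of methoxy, reads as a 1.1-fold lower number from compound 3 to compound 4 (0.06 log units; within the scatter) and so does not separate these two compounds. Changing the whole group on the chain carbon does: the steps are a 12-fold lower number from compound 2 to compound 4 (1.10 log units; beyond the scatter) and a 57-fold lower number from compound 1 to compound 4 (1.75 log units; beyond the scatter), both large, so across these compounds the read-out follows that group, not this carbonyl substituent. The data shown give no reason for this. Still open, from the compounds shown here alone, is whether an amine or a carboxylic acid on the carbonyl carbon would also leave the number in place. A longer chain there remains equally untested by these compounds.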